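A Methyl Added to a Compound Without Measurable Effect

This account rests on a few compounds, and the source may have more. Where it says the series, first, only, none or still open, it means among the compounds named here.

Of the compounds shown here, two have so far been tested in a functional assay on the whole organism (strain Swiss) with Mus musculus as the target, in the maximal electroshock model, with a stated time of 1 h, at a dose of 300 mg/kg by the intraperitoneal route; on this read-out lower numbers stand for a weaker effect and higher numbers for a stronger effect at the one dose given. Compound 1 `COCC(C(=O)N1CCN(c2cccc(C(F)(F)F)c2)CC1)N1C(=O)CCC1=O` gives 100% in this assay. Compound 2 `CC(C(=O)N1CCOCC1)N1C(=O)CCC1=O` gives 0%. Compound 2 thus stands lowest of the two numbers; its nearest neighbour is compound 1, whose number lies higher by a gap beyond the usual scatter. Within the data shown here, the two compounds differ in several places at once, no single structural step is drawn between them, and only their two numbers stand side by side.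

Compound 3 `CCC(C(=O)N1CCOCC1)N1C(=O)CCC1=O` has not yet been measured. It differs from compound 2 in one place only: methyl in place of hydrogen on a saturated chain carbon, two bonds along the chain from an amide-type nitrogen in a ring and a carbonyl carbon. Among the measured compounds shown here, no measured pair shows what such a change does in this assay, and the nearest tested neighbour of compound 2 shares nothing of this change. The step of a number 15 percentage points higher from compound 2 to compound 3 (beyond the scatter) is expected to be small and upward if anything, quite possibly within the scatter. Compound 3 is estimated at 15%, with a range from 0% to 50%.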

Compound 3, a percentage reported as activity, at one dose (the size of the read-out at that dose, not a potency): 0%
For compound 3 the middle estimate is 15 percentage points above the measured one; low and high end bracket the measured number.
By their numbers in this assay, from the lowest: compounds 2 and 3 (each within the scatter of the next); then compound 1.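

Among these compounds, putting methyl in place of hydrogen on a saturated chain carbon, two bonds along the chain from an amide-type nitrogen in a ring and a carbonyl carbon, gives in this assay no change at the digits printed from compound 2 to compound 3 (within the scatter), and this is the first single-place step that can be read here. Since compound 2 already sits at the very bottom of the scale, the step shows only that this one added carbon does not bring a detectable effect at the single dose given, and it cannot show whether the change would weaken an effect, as there is none to lose. No measurement of any other kind bears on this result, so nothing can be said about why the number stays where it is.

Still open, on these data alone, is what a longer chain such as propyl, or a phenyl ring, would do on this same carbon. Also open, as far as these compounds go, is whether a group on this carbon counts for anything when the rest of the molecule is that of compound 1, which gives 100% in this assay.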